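The source may report more compounds than this note shows. Statements on the series, on what has been measured and on what is new or still open speak of the compounds shown alone.

Measured so far in an ADME assay on HepG2 2.2.15 cells (Homo sapiens) for cytotoxicity; on this read-out higher numbers stand for lower toxicity in this test and lower numbers for higher toxicity in this test:
Compound 1 `CCCCCCCC(=O)OCCc1c(-c2ccccc2Cl)c2cc(Cl)ccc2[nH]c1=O`: 78000 nM
Compound 2 `O=C(O)CCCC(=O)OCCc1c(-c2ccccc2Cl)c2cc(Cl)ccc2[nH]c1=O`: 110000 nM

Compound 2 gives 110000 nM, which lies within the scatter of the value for compound 1, so neither compound ranks ahead of the other. Compound 3 `CC(=O)OCC(=O)OCCc1c(-c2ccccc2Cl)c2cc(Cl)ccc2[nH]c1=O` is not yet measured. Relative to compound 2, it carries acetoxy in place of 2-carboxyethyl on a saturated chain carbon bound to a carbonyl carbon. Going by the values given here, the one measured step on this chain is a 1.4-fold higher number from compound 1 to compound 2 (0.15 log units; within the scatter), with carboxy in place of butyl. That single step does not test acetoxy. On this limited evidence, no change beyond the scatter is expected for compound 3 in this assay. The expected step is a 1.2-fold lower number from compound 2 to compound 3 (0.06 log units; within the scatter). Compound 3 is estimated at 95000 nM, with an expected range of 48000 nM to 190000 nM.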

Compound 3, half-maximal cytotoxic concentration: 100000 nM
Estimate against measurement, compound 3: 1.1-fold (0.02 log units) below; low and high end bracket the measured number.
By their numbers in this assay, from the lowest: compounds 1, 3 and 2 (each within the scatter of the next).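

In this assay, acetoxy in place of 2-carboxyethyl on a saturated chain carbon bound to a carbonyl carbon gives a 1.1-fold lower number from compound 2 to compound 3 (0.04 log units; within the scatter), and acetoxy in place of hexyl gives a 1.3-fold higher number from compound 1 to compound 3 (0.11 log units; within the scatter). A third end group, with no hydrogen-bond donor where 2-carboxyethyl has one, thus leaves all three compounds within the scatter of each other, so this position has shown no change beyond the scatter across hexyl, 2-carboxyethyl and acetoxy. No measurement on hand offers an explanation for this flat result.

On these data alone, whether an amine, a ring or a chain longer than hexyl at this position would move the number beyond the scatter remains open. As far as these compounds go, all three compounds share the same core and ester link, so the effect of an amide in place of that ester also remains open.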